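Varying the Aryl Group on the Carbonyl Carbon

The source may hold more compounds than are shown below. What is called first, only, known or untested is meant among the compounds shown, and "the series" means these compounds.

Compound 1 `COc1cc(-c2nnc3n2NC(c2ccco2)C(C(=O)c2ccco2)S3)cc(OC)c1OC`: 68700 nM
Compound 2 `COc1cc(-c2nnc3n2NC(c2ccco2)C(C(=O)c2ccccc2C)S3)cc(OC)c1OC`: 80000 nM

Among the measured compounds shown here, in a functional assay on A549 cells (Homo sapiens) for cytotoxicity, read by MTT assay, with a stated time of 48 h (a lower number here means a stronger inhibitor, a higher number a weaker inhibitor), compound 2 gives 80000 nM, the higher of the two numbers measured; its only neighbour is compound 1, which gives 68700 nM, and the gap between them is within the scatter. That single measured step bears directly on the present question, since it also swaps the aryl group on the carbonyl carbon: a 1.2-fold higher number from compound 1 to compound 2 (0.07 log units; within the scatter). Compound 3 `COc1cc(C(=O)C2Sc3nnc(-c4cc(OC)c(OC)c(OC)c4)n3NC2c2ccco2)cc(OC)c1OC` is not yet measured. It differs from compound 2 in one place: 3,4,5-trimethoxyphenyl in place of 2-methylphenyl on a carbonyl carbon. For the measured compounds named here, because the one comparable step is a 1.2-fold higher number from compound 1 to compound 2 (0.07 log units; within the scatter), no step beyond the scatter is expected in this assay for this change. Compound 3 is therefore expected at 70000 nM, with a range from 25000 nM to 200000 nM. The expected step is a 1.1-fold lower number from compound 2 to compound 3 (0.06 log units; within the scatter), resting on one comparison only.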

Compound 3, half-maximal inhibitory concentration: 48300 nM
Compound 3: middle estimate off by 1.4-fold (0.16 log units), on the high side, and the stated range covers the measured number.
By their numbers in this assay, from the lowest: compounds 3, 1 and 2 (each within the scatter of the next).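

In this assay, the carbonyl carbon now carries 3,4,5-trimethoxyphenyl, with 12 heavy atoms and 3 hydrogen-bond acceptors, in place of 2-methylphenyl, with 7 heavy atoms and 0 hydrogen-bond acceptors, yet the step stays within the scatter (a 1.7-fold lower number from compound 2 to compound 3 (0.22 log units; within the scatter)). The exchange for furan-2-yl reads the same way (a 1.4-fold lower number from compound 1 to compound 3 (0.15 log units; within the scatter)), so the three aryl groups shown on this carbon do not separate from one another, even with this larger group and its added oxygen atoms. No measurement is available that could account for this result.

As far as these compounds go, whether an amine, a carboxylic acid or a longer alkyl chain on the carbonyl carbon would move the number beyond the scatter remains open. From the compounds shown here alone, it is also open whether any other aryl group here would do so.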